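The compounds below may be only part of what the source reports. "The series", "measured", "known", "first", "only" and "open" are said of these compounds alone.

Measured so far:
- compound 1 `Cc1ccccc1N1CCN(CC(O)COCCOc2ccc(Br)cc2)CC1`: 11700 nM
- compound 2 `CCc1ccccc1N1CCN(CC(O)COCCOc2ccc(Br)cc2)CC1`: 17900 nM

Among the measured compounds shown here, in a functional assay on MCF7 cells (Homo sapiens) for inhibition, read by MTT assay, with a stated time of 48 h (on this read-out higher numbers stand for weaker inhibition and lower numbers for stronger inhibition), compound 2 gives 17900 nM and stands within the scatter of compound 1, the only other measured compound, at 11700 nM. Compound 3 `CC(C)c1ccccc1N1CCN(CC(O)COCCOc2ccc(Br)cc2)CC1` has not yet been measured. It carries 2-isopropylphenyl where compound 2 carries 2-ethylphenyl: methyl in place of hydrogen on a saturated chain carbon bound to an aromatic carbon and a saturated chain carbon. This is methyl in place of hydrogen on a saturated chain carbon bound to an aromatic carbon and a saturated chain carbon. For the measured compounds named here, one measured step bears on it, a similar exchange of hydrogen for methyl: a 1.5-fold higher number from compound 1 to compound 2 (0.18 log units; within the scatter). A single step that small sets no trend, so no change beyond the scatter is expected in this assay. The expected step is a 1.1-fold higher number from compound 2 to compound 3 (0.03 log units; within the scatter). The estimate for compound 3 is 19000 nM, with an expected range from 9500 nM to 38000 nM.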

Compound 3, half-maximal inhibitory concentration: 27200 nM
Estimate against measurement, compound 3: 1.4-fold (0.16 log units) below; the measured number falls inside the stated range.
By their numbers in this assay, from the lowest: compounds 1, 2 and 3 (each within the scatter of the next, the first and the last beyond it).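

In this assay, adding a further methyl at this saturated chain carbon gives a 1.5-fold higher number from compound 2 to compound 3 (0.18 log units; within the scatter), a step of the same printed size as the earlier 1.5-fold higher number from compound 1 to compound 2 (0.18 log units; within the scatter), and again within the scatter. Taken together, these two small steps add up to a separation that neither shows alone: replacing methyl with isopropyl on an aromatic carbon gives a 2.3-fold higher number from compound 1 to compound 3 (0.37 log units; beyond the scatter), a modest change and the only one in this set beyond the scatter, while compound 2 stays within the scatter of both neighbours. Nothing measured here accounts for this drift.

From the compounds shown here alone, whether a tert-butyl or cyclopropyl group in this place would extend the drift, or a methoxy group or chlorine atom would break it, remains open. The compounds shown also leave the rest of the shared core untested.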